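Swapping the chain end of compound 2

The source may report more compounds than this note shows. Statements on the series, on what has been measured and on what is new or still open speak of the compounds shown alone.

Among the compounds with values here, in a functional assay on MDA-MB-231 cells (Homo sapiens) for inhibition, read by MTT assay, with a stated time of 72 h (a higher number here means a weaker inhibitor, a lower number a stronger inhibitor), compound 2 `CC(C)COC(=O)NCCOc1ccc(Cl)cc1C(=O)N[C@H](C(=O)Nc1ccc([N+](=O)[O-])cc1Cl)C(C)C` gives 4900 nM as the only true number so far. Compound 1 `CC(C)[C@H](NC(=O)c1cc(Cl)ccc1OCCNC(=O)O)C(=O)Nc1ccc([N+](=O)[O-])cc1Cl` reads > 10000 nM and this is a limit of the assay, not a number. Compound 3 `CC(C)[C@H](NC(=O)c1cc(Cl)ccc1OCCCCNC(=O)OC(C)(C)C)C(=O)Nc1ccc([N+](=O)[O-])cc1Cl` reads > 10000 nM and this too is a limit. Compound 4 `CC(C)[C@H](NC(=O)c1cc(Cl)ccc1OCCCCN)C(=O)Nc1ccc([N+](=O)[O-])cc1Cl` carries 2-aminoethyl in place of (isobutoxycarbonyl)amino on a saturated chain carbon, two bonds along the chain from an oxygen on an aromatic ring, a change counted as 2-aminoethyl in place of (isobutoxycarbonyl)amino on a saturated chain carbon, two bonds along the chain from an oxygen on an aromatic ring here. Within the data shown here, two measured steps touch this same end of the molecule. One is an at least 2.0-fold lower number from compound 1 to compound 2 (0.30 log units; that floor lies within the scatter) and the other, at the very place of the change, is an at least 2.0-fold higher number from compound 2 to compound 3 (0.30 log units; that floor lies within the scatter) and both are floors only. Neither sets a clear direction, so no step beyond the scatter is expected in this assay for this change. The estimate therefore means a 1.0-fold higher number from compound 2 to compound 4 (0.01 log units; within the scatter) as the expected step. Compound 4 is expected at 5000 nM with an estimated range from 1500 nM to 15000 nM in this measurement.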

Compound 4, half-maximal inhibitory concentration: 5590 nM
Compound 4: the middle estimate sits 1.1-fold (0.05 log units) below what was measured, and the stated range covers the measured number.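

Within the data shown here, the step to the free amine is the first at this end of the molecule with a true number on both sides. It reads a 1.1-fold higher number from compound 2 to compound 4 (0.06 log units; within the scatter), so in this assay the 4-aminobutoxy chain and the 2-((isobutoxycarbonyl)amino)ethoxy chain cannot be told apart. Taking off the tert-butoxycarbonyl group gives an at least 1.7-fold lower number from compound 3 to compound 4 (0.25 log units; that floor lies within the scatter), and replacing the carboxyamino end gives an at least 1.7-fold lower number from compound 1 to compound 4 (0.25 log units; that floor lies within the scatter). Both are floors and not sizes, because compound 1 and compound 3 each stop at a limit of the assay: the limit of > 10000 nM in this assay, at which 2 of the 4 values shown sit.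

As far as these compounds go, how far compound 1 and compound 3 truly lie from compound 4 stays open. Also open, from the compounds shown here alone, is how a carboxylic acid, a dimethylamino group or a shorter chain ending in an amine would read at this place.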